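The source may hold more compounds than are shown below. What is called first, only, known or untested is meant among the compounds shown, and "the series" means these compounds.

Working notes on the series built on the core of compound 1 (`O=C(O)CC/C=C\CC1COC(c2ccc(Cl)cc2Cl)OC1c1cccnc1`). In a functional assay for inhibition, with Homo sapiens as the target (a lower number here means tighter binding, a higher number weaker binding), compound 1 gives 891 nM, compound 2 (`O=C(O)CC/C=C\CC1COC(c2ccc(C(F)(F)F)cc2)OC1c1cccnc1`) gives 1780 nM, and compound 3 (`O=C(O)CC/C=C\CC1COC(c2cccs2)OC1c1cccnc1`) gives 1000 nM. Compound 3 stands within the scatter of both others, with a 1.1-fold higher number from compound 1 to compound 3 (0.05 log units; within the scatter) and a 1.8-fold lower number from compound 2 to compound 3 (0.25 log units; within the scatter).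

The next structure is compound 4 (`O=C(O)CC/C=C\CC1COC(c2ccc3ccccc3c2)OC1c1cccnc1`), which carries naphthalen-2-yl in place of thiophen-2-yl on a saturated ring carbon. The measured steps that bear on it are the swaps at this same ring carbon. Besides the two above, there is a 2.0-fold higher number from compound 1 to compound 2 (0.30 log units; within the scatter), and all three lie within the scatter. Going by the values given here, no measured compound carries naphthalen-2-yl, so the expectation is an extrapolation from these three compounds. No step beyond the scatter is expected in this assay, and no direction can be assigned. The expected step is no change at the digits printed from compound 3 to compound 4 (within the scatter). For compound 4 the estimated value is 1000 nM, with an expected range of 400 nM to 2500 nM.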

Compound 4, dissociation constant: 1780 nM
Estimate against measurement, compound 4: 1.8-fold (0.25 log units) below; measured number inside the range.
By their numbers in this assay, from the lowest: compounds 1, 3, 2 and 4 (each within the scatter of the next).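

In this assay, naphthalen-2-yl, with 10 heavy atoms against the 5 of thiophen-2-yl, adds a much larger group at this ring carbon without a step beyond the scatter (a 1.8-fold higher number from compound 3 to compound 4 (0.25 log units; within the scatter)). The same reading holds against the two substituted phenyl groups (no change at the digits printed from compound 2 to compound 4 (within the scatter); a 2.0-fold higher number from compound 1 to compound 4 (0.30 log units; within the scatter)), so the four aromatic groups now seen at this position, from the single five-membered ring to the two six-membered rings, cannot be told apart in this assay. Nothing measured on these compounds accounts for this flat response.

On these data alone, whether it extends to a non-aromatic group at this ring carbon, such as an amine or a carboxylic acid, remains open. Also open, as far as these compounds go, is what a longer chain in place of the 5-carboxypent-2-en-1-yl group would do to the number.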